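The source may report more compounds than this note shows. Statements on the series, on what has been measured and on what is new or still open speak of the compounds shown alone.

The measured compounds so far:

Compound 1, `O=C(/C=C/c1ccc(Cl)cc1)NCCO`: in a functional assay on the whole organism (strain Kunming) with Mus musculus as the target, in the maximal electroshock model (a lower number here means that less compound is needed, a higher number that more compound is needed for the effect), compound 1 gives 73.4 mg/kg.
Compound 2, `O=C(/C=C/c1ccc(Br)cc1)NCCO`: in this assay compound 2 gives 76 mg/kg.
Compound 3, `O=C(/C=C/c1ccccc1Cl)NCCO`: in this assay compound 3 gives 59 mg/kg.

Compounds 1 and 2 share one core and differ in a single place: bromo in place of chloro on an aromatic carbon. That swap produced a 1.0-fold higher number from compound 1 to compound 2 (0.02 log units; within the scatter), so the two halogens behaved alike there. Compound 3 is built from the same atoms as compound 1, joined differently; the difference between the two cores is not broken down here. The values of compounds 1, 2 and 3 all lie within the usual scatter of one another, so no order among them can be read from these numbers.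

Compound 4, `O=C(/C=C/c1ccccc1Br)NCCO`, has not yet been tested in this assay. It differs from compound 3 in one place: bromo in place of chloro on an aromatic carbon. Going by the values given here, this is the same kind of change as the one from compound 1 to compound 2, but not the same: in compound 2 the bromo sits para to a group of 8 heavy atoms, whereas in compound 4 it sits ortho to a group of 8 heavy atoms. Because the earlier swap gave a 1.0-fold higher number from compound 1 to compound 2 (0.02 log units; within the scatter), the step is expected to be a 1.0-fold higher number from compound 3 to compound 4 (0.01 log units; within the scatter), with some allowance for the different place. Compound 4 is therefore estimated to give 60 mg/kg, with the estimate spanning 38 mg/kg to 95 mg/kg.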

Compound 4, dose for half-maximal effect: 68.2 mg/kg
Estimate against measurement, compound 4: 1.1-fold (0.06 log units) below; low and high end bracket the measured number.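

In this assay, going by these compounds alone, putting bromo in place of chloro on an aromatic carbon, ortho to a group of 8 heavy atoms, gave a 1.2-fold higher number from compound 3 to compound 4 (0.06 log units; within the scatter), so this swap again produced no step that can be told apart from the noise of repeated measurements. Set beside the earlier case, the two steps agree, which means that within this small set the swap carried over from one core to the other without any detectable difference: the same change on two cores in this assay, a 1.0-fold higher number (0.02 log units; within the scatter) from compound 1 to compound 2 and a 1.2-fold higher number (0.06 log units; within the scatter) from compound 3 to compound 4, 1.1-fold (0.05 log units) apart, within the scatter of two such steps

This does not show that bromo and chloro are truly equal, only that any difference between them is too small for this assay to resolve, and two pairs cannot establish that the same would hold on other cores of the series.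

The compounds shown leave open what happens when the ring carries something other than these two halogens, such as fluoro, methoxy or an amine. They also leave open how the number would respond if the chain ending in a hydroxyl group gave way to a longer chain or to one ending in a carboxylic acid.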